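The source may report more compounds than this note shows. Statements on the series, on what has been measured and on what is new or still open speak of the compounds shown alone.

Measured so far:
compound 1 `Cc1ccc(CN2CCC(NC(=O)N(CC(=O)C(C)(C)O)Cc3ccc(-c4ccc(F)cc4)cc3)CC2)cc1` — 4530 nM
compound 2 `COc1ccc(-c2ccc(CN(CC(=O)C(C)(C)O)C(=O)NC3CCN(Cc4ccc(C)cc4)CC3)cc2)cc1` — > 10000 nM

In an in vitro functional assay on HEK293 cells for antagonist activity at melanin-concentrating hormone receptor 1 (Homo sapiens), read by GTPgammaS binding, with a stated time of 45 min (a higher number here means a weaker inhibitor, a lower number a stronger inhibitor), compound 1 gives 4530 nM. For compound 2 the assay reports only a limit, > 10000 nM, so compound 2 has no exact number and stands at the weak end of the pair. The step of an at least 2.2-fold higher number from compound 1 to compound 2 (0.34 log units; beyond the scatter) is bounded only because of the limit of > 10000 nM in this assay, at which 1 of the 2 values shown sits. Compound 3 `COc1ccccc1-c1ccc(CN(CC(=O)C(C)(C)O)C(=O)NC2CCN(Cc3ccc(C)cc3)CC2)cc1` differs from compound 2 by 2-methoxyphenyl in place of 4-methoxyphenyl on an aromatic carbon. Among the measured compounds shown here, no measured step tests this rearrangement, so no change beyond the scatter is expected in this assay. Compound 3 is estimated at 10000 nM, between 3000 nM and 30000 nM. The expected step is a number no higher from compound 2 to compound 3 (the limit leaves the size open).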

Compound 3, antagonist equilibrium constant: 3730 nM
For compound 3 the middle estimate is 2.7-fold (0.43 log units) above the measured one; measured number inside the range.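

Where the methoxy group sits on this ring matters in this assay: 2-methoxyphenyl in place of 4-methoxyphenyl gives an at least 2.6-fold lower number from compound 2 to compound 3 (0.42 log units; beyond the scatter). Only a lower bound on the size of that step can be read: the limit of > 10000 nM in this assay, at which 1 of the 3 values shown sits. The 2-methoxyphenyl and 4-fluorophenyl groups cannot be told apart here, with a 1.2-fold lower number from compound 1 to compound 3 (0.08 log units; within the scatter).

From the compounds shown here alone, how a hydroxyl group or an amine on this ring would read in this assay stays open. So does the exact number for compound 2, which has only a limit.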